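Trading a Methoxyphenyl for a Methylphenyl Group

This account rests on a few compounds, and the source may have more. Where it says the series, first, only, none or still open, it means among the compounds named here.

Compound 1 `CC(C)c1ccc(-c2nc(SCc3cn(CC(=O)NC(=O)Nc4ccccn4)nn3)nc(Nc3ccc(F)cc3)c2C#N)cc1`: 17500 nM
Compound 2 `CC(C)c1ccc(-c2nc(SCc3cn(CC(=O)NC(=O)Nc4ccccn4)nn3)nc(Nc3ccccc3)c2C#N)cc1`: 15800 nM
Compound 3 `COc1ccc(Nc2nc(SCc3cn(CC(=O)NC(=O)Nc4ccccn4)nn3)nc(-c3ccc(C(C)C)cc3)c2C#N)cc1`: > 64000 nM (a limit)

All three compounds were tested in a functional assay on MGC-803 cells (Homo sapiens) for inhibition, read by MTT assay, with a stated time of 72 h; on this read-out lower numbers stand for stronger inhibition and higher numbers for weaker inhibition. Going by these compounds, for compound 3 the result is only a limit, (the limit of > 64000 nM in this assay, at which 1 of the 3 values shown sits), so its true value is unknown beyond that boundary. Compounds 1 and 2 sit close together, and the step of a 1.1-fold lower number from compound 1 to compound 2 (0.04 log units; within the scatter) shows that hydrogen in place of fluoro makes no clear difference. Against that, an at least 3.6-fold higher number from compound 1 to compound 3 (0.56 log units; beyond the scatter) and an at least 4.0-fold higher number from compound 2 to compound 3 (0.60 log units; beyond the scatter) show that methoxy on that ring weakens inhibition at least modestly.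

Compound 4 `Cc1cccc(Nc2nc(SCc3cn(CC(=O)NC(=O)Nc4ccccn4)nn3)nc(-c3ccc(C(C)C)cc3)c2C#N)c1` has not yet been measured. It differs from compound 3 by 3-methylphenyl in place of 4-methoxyphenyl on a nitrogen on an aromatic ring. Since the two steps toward compound 3 both point to the methoxy group as the change that weakened inhibition, removing it is expected to bring the number back toward those of compounds 1 and 2, although a methylphenyl ring is not identical to either of those. The expected step is an at least 2.5-fold lower number from compound 3 to compound 4 (0.40 log units; beyond the scatter), a decrease of uncertain size given that compound 3 is only a limit. Compound 4 is therefore estimated at 25000 nM, with a likely range from 10000 nM to 64000 nM.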

Compound 4, half-maximal inhibitory concentration: 25300 nM
For compound 4 the middle estimate is 1.0-fold (0.01 log units) below the measured one; the range from low to high includes it.
By their numbers in this assay, from the lowest: compounds 2, 1 and 4 (each within the scatter of the next). At a limit, above all of these: compound 3.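

In this assay, an at least 2.5-fold lower number from compound 3 to compound 4 (0.40 log units; beyond the scatter) shows that the loss seen with the (4-methoxyphenyl)amino group does not extend to every substituted ring at this position. This step starts from compound 3, whose value is only a limit: the limit of > 64000 nM in this assay, at which 1 of the 4 values shown sits. With a 1.6-fold higher number from compound 2 to compound 4 (0.20 log units; within the scatter) and a 1.4-fold higher number from compound 1 to compound 4 (0.16 log units; within the scatter), both within the scatter, the (3-methylphenyl)amino group reads the same as the unsubstituted and 4-fluorophenyl rings, so among these four compounds, a ring substituent does not by itself weaken inhibition, and only compound 3 goes against this.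

Compound 4 changes both the group and its place on the ring, so these compounds cannot show whether the methoxy group itself or its place matters. Going by these compounds, how an amine or a carboxylic acid on this ring would read also remains open.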